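From Methyl to Phenyl: Estimating Compound 3

The source may report more compounds than this note shows. Statements on the series, on what has been measured and on what is new or still open speak of the compounds shown alone.

Of the compounds shown here, two built on one shared core have been measured in a functional assay (FL5.12 cells, Mus musculus) with Apoptosis regulator Bcl-2 (Homo sapiens) as the target; a higher number here means that more compound is needed for the effect, a lower number that less compound is needed. Compound 1 `CC1(C)CCN(c2ccc(C(=O)NS(=O)(=O)c3ccc(NC(C)(C)CSc4ccccc4)c([N+](=O)[O-])c3)cc2)CC1` gives 2200 nM in this assay. Compound 2 `COC1(Cc2ccccc2C)CCN(c2ccc(C(=O)NS(=O)(=O)c3ccc(N[C@H](CCN(C)C)CSc4ccccc4)c([N+](=O)[O-])c3)cc2)CC1` gives 200 nM in this assay, the lower of the two numbers, and its distance to compound 1 lies well beyond the usual scatter of repeated measurements.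

Compound 3 `COC1(Cc2ccccc2-c2ccccc2)CCN(c2ccc(C(=O)NS(=O)(=O)c3ccc(N[C@H](CCN(C)C)CSc4ccccc4)c([N+](=O)[O-])c3)cc2)CC1` has not yet been measured. It differs from compound 2 in a single place: phenyl in place of methyl on an aromatic carbon. Within the data shown here, no measured pair of compounds shows this particular change, so there is nothing here to say how a phenyl at that position compares with a methyl. In the absence of such a pair, the expected step of a 1.1-fold lower number from compound 2 to compound 3 (0.05 log units; within the scatter) is small, with no clear direction beyond the usual scatter. Compound 3 is therefore estimated at 180 nM in this assay, within a range from 50 nM to 650 nM.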

Compound 3, half-maximal effective concentration: 20 nM
Beside the measured number, compound 3's estimate is 9.0-fold (0.95 log units) above it; the measured number lies below the stated range.
By their numbers in this assay, from the lowest: compound 3; then compound 2; then compound 1.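

In this assay, phenyl in place of methyl on this aromatic carbon, ortho to a large group, gives a 10-fold lower number from compound 2 to compound 3 (1.00 log units; beyond the scatter). Among these compounds, this is the first look at a single change: compound 1 and compound 2 differ in more than one place, whereas this step shows that the group at this one position alone can move the number well beyond the scatter, and that going from 2-methylphenyl to 2-phenylphenyl moves it downward. Nothing shown here accounts for the size of this step.

Still open, on these data alone, is whether an aromatic ring is needed at this position, or whether a cyclohexyl ring or a longer chain such as propyl would do the same. The compounds shown also leave open how an amine or a carboxylic acid on the new phenyl would shift the number.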